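A Methyl-to-Trifluoromethyl Change Made Twice

The source may report more compounds than this note shows. Statements on the series, on what has been measured and on what is new or still open speak of the compounds shown alone.

Compound 1 `Cc1cccc([S+]([O-])c2cccc(N)c2C#N)c1`: in a functional assay on MT4 cells (Homo sapiens) for cytotoxicity (a lower number here means a stronger inhibitor, a higher number a weaker inhibitor), compound 1 gives > 200000 nM, which is a limit of the assay rather than a number.
Compound 2 `N#Cc1c(N)cccc1[S+]([O-])c1cccc(C(F)(F)F)c1`: in this assay compound 2 gives 125000 nM.
Compound 3 `COc1cc(C)cc(S(=O)(=O)c2cccc(N)c2C#N)c1`: in this assay compound 3 gives 94000 nM.

The change from compound 1 to compound 2 is trifluoromethyl in place of methyl on an aromatic carbon. It made an at least 1.6-fold lower number from compound 1 to compound 2 (0.20 log units; that floor lies within the scatter), a step whose size is known only as a floor because of the limit of > 200000 nM in this assay, at which 1 of the 3 values shown sits.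

Compound 4 `COc1cc(C(F)(F)F)cc(S(=O)(=O)c2cccc(N)c2C#N)c1` is not yet measured. It differs from compound 3 by trifluoromethyl in place of methyl on an aromatic carbon. This is the same kind of change, though here the place is also meta to a methoxy group. The difference between the core of compound 1 and the core of compound 3 is not broken down here.

For compound 4 in this assay a step of a 1.6-fold lower number from compound 3 to compound 4 (0.19 log units; within the scatter) is expected, resting on the step from compound 1 to compound 2, an at least 1.6-fold lower number from compound 1 to compound 2 (0.20 log units; that floor lies within the scatter). Compound 4 is therefore estimated at 60000 nM, between 25000 nM and 150000 nM.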

Compound 4, half-maximal inhibitory concentration: 164000 nM
The estimate for compound 4 lay 2.7-fold (0.44 log units) below the measured number; the measured number lies above the stated range.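

On the core of compound 3, trifluoromethyl in place of methyl gave a 1.7-fold higher number from compound 3 to compound 4 (0.24 log units; within the scatter) in this assay. Set beside the earlier step, this shows that the change did not carry over from one core to the other as a step of the same size: the same change on two cores in this assay, an at least 1.6-fold lower number (0.20 log units; that floor lies within the scatter) from compound 1 to compound 2 and a 1.7-fold higher number (0.24 log units; within the scatter) from compound 3 to compound 4, at least 2.7-fold (0.44 log units) apart, beyond the scatter of two such steps It does not show why the two steps part, and the earlier step is known only as a floor, with compound 1 sitting at a limit rather than a number: the limit of > 200000 nM in this assay, at which 1 of the 4 values shown sits.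

The compounds shown leave open which of the differences between the core of compound 1 and the core of compound 3 goes with this gap. They also leave open how an amine, a carboxylic acid or a longer chain in place of methyl would read in this assay.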